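Cytotoxicity Outlook for a Larger Side Group

A few compounds are considered here, and "the series" means these few. Any claim that something is new, unique, unknown or untested is made for them only; others in the source may bear on it.

In an ADME assay on CHO cells (Cricetulus griseus) for cytotoxicity, read by MTT assay (on this read-out lower numbers stand for stronger inhibition and higher numbers for weaker inhibition), compound 2 `CCc1cc(C)nn1-c1nc(C(F)(F)F)cc(=O)[nH]1` gives 108000 nM, the only numerical result among the two compounds measured. Compound 1 `Cc1cc(C)n(-c2nc(-c3ccc(S(C)(=O)=O)cc3)cc(=O)[nH]2)n1` gives no number but a limit of the assay, > 50000 nM, which is the limit of > 50000 nM in this assay, at which 1 of the 2 values shown sits. Compound 3 `Cc1cc(Nc2ccc(F)cc2)n(-c2nc(C(F)(F)F)cc(=O)[nH]2)n1` has not yet been measured. It differs from compound 2 by (4-fluorophenyl)amino in place of ethyl on an aromatic carbon. Going by the values given here, no step between measured compounds exists here. Compound 3 is expected to remain weakly cytotoxic, so the step of a 1.8-fold lower number from compound 2 to compound 3 (0.26 log units; within the scatter) is estimated to stay within the usual scatter. Compound 3 is therefore estimated at 60000 nM, between 20000 nM and 150000 nM.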

Compound 3, half-maximal inhibitory concentration: 20000 nM
Beside the measured number, compound 3's estimate is 3.0-fold (0.48 log units) above it, within the range that was stated.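

Putting (4-fluorophenyl)amino in place of ethyl on this aromatic carbon gives a 5.4-fold lower number from compound 2 to compound 3 (0.73 log units; beyond the scatter) in this assay. Going by these compounds alone, this shows that the group at this position can shift the read-out, which the earlier compounds could not show, as no step linked them. Nothing shown gives a reason for this step.

As far as these compounds go, it remains open whether the step follows from the aromatic ring, the fluorine or the linking nitrogen. Also open, from the compounds shown here alone, is what a plain amino group, a phenyl group or a longer alkyl chain would give at this position.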